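The source may report more compounds than this note shows. Statements on the series, on what has been measured and on what is new or still open speak of the compounds shown alone.

The compounds share the core of compound 1 `O=C(O)CCn1c(=O)oc2cc(OCc3ccccc3)c(Cl)cc21`, whose entry in a physicochemical assay for permeability, using PAMPA (on this read-out lower numbers stand for lower permeability and higher numbers for higher permeability), is "not determined" (no result reported). Compound 2 `O=C(O)CCn1c(=O)oc2cc(OCC3CCC3)c(Cl)cc21` gives 12 nm/s in this assay. Compound 3 `C[C@@H](Oc1cc2oc(=O)n(CCC(=O)O)c2cc1Cl)c1ncccn1` reaches only a limit of this assay, < 3 nm/s. Among the numbers shown, compound 3 therefore stands at the bottom, at the limit of < 3 nm/s in this assay, at which 1 of the 3 values shown sits. Within the data shown here, the single measured step, an at least 4.0-fold lower number from compound 2 to compound 3 (0.60 log units; beyond the scatter), runs down to that limit, and this step is the only one that bears on the present question at all: it shows that the pyrimidin-2-yl-bearing side chain of compound 3 lowers the number out of the measurable window, but it says nothing directly about the change now considered.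

Compound 4 `C[C@@H](Oc1cc2oc(=O)n(CCC(=O)O)c2cc1Cl)c1ncco1` differs from compound 3 by 1,3-oxazol-2-yl in place of pyrimidin-2-yl on a saturated chain carbon bound to an oxygen on an aromatic ring and a saturated chain carbon. Since the two exchanged groups are alike in what that difference counts, and since compound 3 already sits at the limit with < 3 nm/s, the author expects no movement beyond the scatter, that is a number no lower from compound 3 to compound 4 (the limit leaves the size open). For compound 4 he estimates 3 nm/s in this assay, with a range from 1 nm/s to 8 nm/s, and he judges it likely that the assay again returns only a limit rather than a number.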

Compound 4, apparent permeability: < 3 nm/s
Compound 4 gave a limit, no number (the forecaster's own chance of this, stated with the estimate: 60%); the middle value lies on the limit itself.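

The 1,3-oxazol-2-yl group on a saturated chain carbon bound to an oxygen on an aromatic ring and a saturated chain carbon leaves the read-out in this assay at a limit, so the earlier finding for pyrimidin-2-yl is no longer confined to a single aromatic ring: the limit of < 3 nm/s in this assay, at which 2 of the 4 values shown sit.

Among these compounds, measured against compound 2, the new side chain gives an at least 4.0-fold lower number from compound 2 to compound 4 (0.60 log units; beyond the scatter), so a five-membered aromatic ring with 2 hetero atoms at this place also brings the read-out down from the one number. The step between the two limits cannot be read, so the data do not place pyrimidin-2-yl and 1,3-oxazol-2-yl in any order.

Going by these compounds, how far either compound lies under the limit stays open, and so does any difference between the two rings. Also open, on these data alone, is whether a cyclopropyl or a pyridin-2-yl group on this saturated chain carbon would return a number in this assay at all, or whether an ester in place of the carboxylic acid of the shared chain would do so.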